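The compounds below may be only part of what the source reports. "The series", "measured", "known", "first", "only" and "open" are said of these compounds alone.

In a functional assay on PC-3 cells (Homo sapiens) for cytotoxicity, read by MTT assay, with a stated time of 72 h (a higher number here means a weaker inhibitor, a lower number a stronger inhibitor), three compounds have so far been measured:

compound 1, `O=C(N/N=C/c1cccc(Cl)c1Cl)Nc1cc2c(Nc3ccc(F)c(Cl)c3)ncnc2cc1O[C@H]1CCOC1`, gives 27400 nM
compound 2, `COc1ccc(/C=N/NC(=O)Nc2cc3c(Nc4ccc(F)c(Cl)c4)ncnc3cc2O[C@H]2CCOC2)cc1`, gives 34100 nM
compound 3, `COc1cc2ncnc(Nc3ccc(F)c(Cl)c3)c2cc1NC(=O)N/N=C/c1cccc(Cl)c1Cl`, gives 24400 nM

All three share a core built around the same aryl-amino heterocycle and the same acylhydrazone arm; they differ only at two points. Compound 2 differs from compound 1 by one change, (4-methoxyphenyl in place of 2,3-dichlorophenyl on a carbon with a double bond to nitrogen). That change produced a 1.2-fold higher number from compound 1 to compound 2 (0.10 log units; within the scatter), so the two numbers are, for practical purposes, the same. Compound 3 differs from compound 1 at the other point, (methyl in place of oxolan-3-yl on an oxygen on an aromatic ring), and that change gave a 1.1-fold lower number from compound 1 to compound 3 (0.05 log units; within the scatter), again a difference too small to read as real. Taken together, the three values show no separation that can be trusted.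

Compound 4, `COc1ccc(/C=N/NC(=O)Nc2cc3c(Nc4ccc(F)c(Cl)c4)ncnc3cc2OC)cc1`, has not yet been measured in this assay. It differs from compound 3 by 4-methoxyphenyl in place of 2,3-dichlorophenyl on a carbon with a double bond to nitrogen. This is the same change that turns compound 1 into compound 2, made on the same kind of carbon with the same neighbours; only the core around it differs, by the change described between compound 1 and compound 3.

Because the earlier instance of this change gave a 1.2-fold higher number from compound 1 to compound 2 (0.10 log units; within the scatter), the expected step here is similar and small, a 1.2-fold higher number from compound 3 to compound 4 (0.08 log units; within the scatter), which means the estimate for compound 4 in this assay is around 29000 nM, most likely between 15000 nM and 58000 nM.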

Compound 4, half-maximal inhibitory concentration: 16500 nM
Compound 4: middle estimate off by 1.8-fold (0.24 log units), on the high side; measured number inside the range.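

In this assay, putting 4-methoxyphenyl in place of 2,3-dichlorophenyl gave a 1.5-fold lower number from compound 3 to compound 4 (0.17 log units; within the scatter), and this step agrees with the same swap made on the core of compound 1: the same change on two cores in this assay, a 1.2-fold higher number (0.10 log units; within the scatter) from compound 1 to compound 2 and a 1.5-fold lower number (0.17 log units; within the scatter) from compound 3 to compound 4, 1.8-fold (0.26 log units) apart, within the scatter of two such steps. Putting methyl in place of oxolan-3-yl on the oxygen on the aromatic ring gave a 2.1-fold lower number from compound 2 to compound 4 (0.32 log units; beyond the scatter), a modest step that is the only one here to pass beyond the scatter, yet it also agrees with its earlier counterpart: the same change on two cores in this assay, a 1.1-fold lower number (0.05 log units; within the scatter) from compound 1 to compound 3 and a 2.1-fold lower number (0.32 log units; beyond the scatter) from compound 2 to compound 4, 1.8-fold (0.26 log units) apart, within the scatter of two such steps. Each change therefore carried from one core to the other with no detectable difference, but this rests on just two pairs per change, all with small steps, so it shows only that no dependence on the core can be seen here, not that the steps are truly identical or that they would hold on other cores.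

The compounds shown leave open whether a quite different group on the carbon with a double bond to nitrogen, such as a phenyl ring carrying an amine or a carboxylic acid, would give a larger step. They also leave open whether a longer chain ending in an amine, placed on the oxygen on the aromatic ring, would move the number further than methyl or oxolan-3-yl does.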